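A few compounds are considered here, and "the series" means these few. Any claim that something is new, unique, unknown or untested is made for them only; others in the source may bear on it.

Of the compounds shown here, three share one core and have been tested in a functional assay on NCI-H460 cells (Homo sapiens) for cytotoxicity, read by sulforhodamine B assay, with a stated time of 48 h, tested at 100 nM; on this read-out higher numbers stand for a weaker effect at the one concentration tested and lower numbers for a stronger effect. Compound 1, `COc1cc(C)cc(-c2nn(CC#N)cc2-c2ccc(-c3cccc(C(C)=O)c3)nc2)c1`, gives 84%. Compound 2, `Cc1cc(O)cc(-c2nn(CC#N)cc2-c2ccnc(-c3ccc(Oc4ccccc4)cc3)c2)c1`, gives 99%. Compound 3, `COc1cc(C)cc(-c2nn(CC#N)cc2-c2ccnc(-c3ccc(N(C)C)cc3)c2)c1`, gives 8%, the lowest of the three numbers, so it shows the strongest effect at the single concentration used; its gap to compound 1 and its larger gap to compound 2 both lie beyond the usual scatter. Among the measured compounds shown here, none of these three differs from another in only one place, so no single step between measured compounds can be read from them.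

Compound 4, `Cc1cc(O)cc(-c2nn(CC#N)cc2-c2ccnc(-c3ccc(N(C)C)cc3)c2)c1`, is the next compound to be measured in this assay. It differs from compound 3 in one place: hydrogen in place of methyl on an oxygen on an aromatic ring. Compound 2 also carries a hydroxy group on its 3-hydroxy-5-methylphenyl ring, but it differs from compound 4 elsewhere as well. The value of compound 2, 99%, therefore cannot be turned into a step.

Without a measured step for this change, the expectation for compound 4 rests on the strong effect of compound 3 at 8%, with room for some loss. The step from compound 3 to compound 4 is expected to be a number 22 percentage points higher from compound 3 to compound 4 (beyond the scatter), a modest weakening. Compound 4 is therefore estimated at 30%, within a range from 8% to 75%.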

Compound 4, a percentage reported as activity, at one concentration (the size of the read-out at that concentration, not a potency): 90%
Compound 4: the middle estimate sits 60 percentage points below what was measured; the whole stated range lies below it.
By their numbers in this assay, from the lowest: compound 3; then compounds 1, 4 and 2 (each within the scatter of the next, the first and the last beyond it).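

In this assay, the change from methoxy to hydroxy on the 3-methoxy-5-methylphenyl ring is the only difference between the two compounds, and it alone carries a large loss of effect: a number 82 percentage points higher from compound 3 to compound 4 (beyond the scatter). So a single methyl on that oxygen separates a strong effect from a weak one, and the dimethylamino group shared by both compounds does not keep the effect once the hydroxy group is present. With the hydroxy group in place, dimethylamino in place of phenoxy leaves the two compounds indistinguishable: a number 9 percentage points lower from compound 2 to compound 4 (within the scatter). No measurement here explains why removing this methyl matters so much.

The compounds shown carry only methoxy or hydroxy at this place, so it remains open whether an ethoxy group, a longer chain on the oxygen, or an amine in place of the oxygen would keep the effect of compound 3. As far as these compounds go, it also remains open whether the methoxy group would give a strong effect alongside phenoxy, since the step from dimethylamino to phenoxy is read here only with the hydroxy group present.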